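The source may report more compounds than this note shows. Statements on the series, on what has been measured and on what is new or still open speak of the compounds shown alone.

In an ADME assay on BHK-21 cells (Mesocricetus auratus) for cytotoxicity, read by MTT assay, with a stated time of 72 h (on this read-out higher numbers stand for lower toxicity in this test and lower numbers for higher toxicity in this test), compound 1 `NS(=O)(=O)c1ccc(N2N=C(c3ccccc3)CC2c2ccccc2Cl)cc1` gives 13000 nM, compound 2 `NS(=O)(=O)c1ccc(N2N=C(c3ccc(Oc4ccccc4)cc3)CC2c2ccccc2)cc1` gives 11000 nM and compound 3 `Cc1ccc(C2CC(c3ccc(Oc4ccccc4)cc3)=NN2c2ccc(S(N)(=O)=O)cc2)cc1` gives 8000 nM, which places compound 3 within the scatter of both others. Compound 4 `NS(=O)(=O)c1ccc(N2N=C(c3ccc(Oc4ccccc4)cc3)CC2c2ccccc2Cl)cc1` carries 2-chlorophenyl in place of 4-methylphenyl on a saturated ring carbon. Within the data shown here, the one measured step touching this position is a 1.4-fold lower number from compound 2 to compound 3 (0.14 log units; within the scatter), for methyl in place of hydrogen on an aromatic carbon, and it stays within the scatter. Compound 1, which already bears 2-chlorophenyl there, also sits within the scatter of compound 3. No change beyond the scatter is therefore expected, and the estimated step is a 1.3-fold higher number from compound 3 to compound 4 (0.10 log units; within the scatter). For compound 4 the expected value is 10000 nM, with an estimated range of 5000 nM to 20000 nM.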

Compound 4, half-maximal cytotoxic concentration: 8000 nM
Estimate against measurement, compound 4: 1.3-fold (0.10 log units) above; the range from low to high includes it.
By their numbers in this assay, from the lowest: compounds 3, 4, 2 and 1 (each within the scatter of the next).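

In this assay 2-chlorophenyl in place of 4-methylphenyl on the saturated ring carbon gives no change at the digits printed from compound 3 to compound 4 (within the scatter), and chloro in place of hydrogen on the same aryl group gives a 1.4-fold lower number from compound 2 to compound 4 (0.14 log units; within the scatter). With 2-chlorophenyl held at this position, adding the phenoxy group gives a 1.6-fold lower number from compound 1 to compound 4 (0.21 log units; within the scatter) as well. Phenyl, 4-methylphenyl and 2-chlorophenyl at this position, each alongside the phenoxy group, thus sit within the scatter of one another. From the compounds shown here alone, whether an amine or a carboxylic acid on this aryl group, or a longer chain in its place, would move the number beyond the scatter stays open. Nothing at hand gives a reason for these numbers.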